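Amide variation on the acrylamide side chain of a naphthyl-pyridine core

This account rests on a few compounds, and the source may have more. Where it says the series, first, only, none or still open, it means among the compounds named here.

Measured compounds:
compound 1, `O=C(O)CCNC(=O)/C=C/c1ccncc1-c1ccc2ccccc2c1`, 870 nM
compound 2, `O=C(/C=C/c1ccncc1-c1ccc2ccccc2c1)N1CCOCC1`, 60.3 nM

Both were run in an assay on a protein complex for inhibition of CDK8/Cyclin C (Homo sapiens), with a stated time of 1 h; a lower number here means a stronger inhibitor, a higher number a weaker inhibitor. Among the measured compounds shown here, compound 2 holds the lower of the two numbers; its nearest neighbour is compound 1, and the single step between them, a 14-fold lower number from compound 1 to compound 2 (1.16 log units; beyond the scatter), shows that the group on the amide carbonyl governs the read-out strongly in this small set.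

The next compound, compound 3, `NC(=O)/C=C/c1ccncc1-c1ccc2ccccc2c1`, carries the change (amino in place of morpholin-4-yl on a carbonyl carbon). For the measured compounds named here, only the step from compound 1 to compound 2 bears on it, and that step was large. A change of comparable size is therefore plausible here, but its direction cannot be read from the two numbers shown. Compound 3 is expected to land at 200 nM, within 50 nM to 800 nM. That estimate corresponds to an expected step of a 3.3-fold higher number from compound 2 to compound 3 (0.52 log units; beyond the scatter).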

Compound 3, half-maximal inhibitory concentration: 10.5 nM
For compound 3 the middle estimate is 19-fold (1.28 log units) above the measured one; measured number outside the range, below it.
By their numbers in this assay, from the lowest: compound 3; then compound 2; then compound 1.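

In this assay the morpholin-4-yl ring is not required on this carbonyl carbon: amino, with a single heavy atom, takes its place and gives the lowest number of the set (a 5.7-fold lower number from compound 2 to compound 3 (0.76 log units; beyond the scatter)). Hydrogen in place of 2-carboxyethyl on the amide-type nitrogen gives a larger step (an 83-fold lower number from compound 1 to compound 3 (1.92 log units; beyond the scatter)), so compound 3 stands below both other compounds, with each step beyond the scatter. No supporting measurement is available to account for either step.

From the compounds shown here alone, whether a single methyl group or a longer alkyl chain on the amide nitrogen would keep the number close to that of compound 3 remains open. Also open, going by these compounds, is how much of the higher number of compound 1 belongs to its carboxylic acid and how much to the chain that carries it.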